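The source may report more compounds than this note shows. Statements on the series, on what has been measured and on what is new or still open speak of the compounds shown alone.

Measured so far:
- compound 1 `COc1ccc(/C=C/C(=O)/C=C/c2ccc(OCc3cn(CCCCCOc4cc(=O)oc5ccccc45)nn3)c(OC)c2)cc1`: 35%
- compound 2 `COc1cc(/C=C/C(=O)/C=C/c2ccccc2)ccc1OCc1cn(CCCCCOc2cc(=O)oc3ccccc23)nn1`: 24%

For the measured compounds named here, in a functional assay on HCT-116 cells (Homo sapiens) for inhibition, read by sulforhodamine B assay, with a stated time of 48 h, tested at 50 uM (on this read-out higher numbers stand for more inhibition of growth at the one concentration tested and lower numbers for less inhibition of growth), compound 2 stands at 24%, the lower of the two numbers, with compound 1 as its only neighbour at 35%. The next compound, compound 3 `COc1cc(/C=C/C(=O)/C=C/c2ccco2)ccc1OCc1cn(CCCCCOc2cc(=O)oc3ccccc23)nn1`, differs from compound 2 by one exchange: furan-2-yl in place of phenyl on a double-bonded chain carbon bound to a double-bonded chain carbon. Furan-2-yl takes the place of phenyl on a double-bonded chain carbon bound to a double-bonded chain carbon. Going by the values given here, only one measured step is available, a number 11 percentage points lower from compound 1 to compound 2 (beyond the scatter), which comes with hydrogen in place of methoxy on an aromatic carbon. That is a different change, so it gives only a rough sense of scale and no direction. Among the compounds with values here, no measured step exchanges phenyl for furan-2-yl, so no shift beyond the scatter is expected. The expected change is a number 3 percentage points higher from compound 2 to compound 3 (within the scatter). For compound 3 the estimated value is 27%, with an expected range of 13% to 41%.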

Compound 3, percent growth inhibition at one concentration: 37%
Beside the measured number, compound 3's estimate is 10 percentage points below it; measured number inside the range.
By their numbers in this assay, from the lowest: compound 2; then compounds 1 and 3 (each within the scatter of the next).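

In this assay, furan-2-yl in place of phenyl on a double-bonded chain carbon bound to a double-bonded chain carbon gives a number 13 percentage points higher from compound 2 to compound 3 (beyond the scatter) and so shows that this place responds to an exchange of the aromatic ring. Furan-2-yl in place of 4-methoxyphenyl at the same place gives a number 2 percentage points higher from compound 1 to compound 3 (within the scatter) and leaves these two groups indistinguishable here, while compound 2 with its phenyl stands apart from both. Nothing measured here accounts for these steps.

From the compounds shown here alone, whether the step from phenyl is specific to furan-2-yl remains open, as thiophen-2-yl or pyridin-2-yl at this place could show. Also open, going by these compounds, is whether a phenyl ring carrying an amine or a carboxylic acid would follow compound 2 or compound 3.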